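Removing One Methyl Group from a Cytotoxicity Series

The source may report more compounds than this note shows. Statements on the series, on what has been measured and on what is new or still open speak of the compounds shown alone.

Of the compounds shown here, two built on one shared core have been tested in an ADME assay on Vero cells (Chlorocebus sabaeus) for cytotoxicity, with a stated time of 72 h, tested at 10 ug/mL; on this read-out higher numbers stand for a stronger effect at the one concentration tested and lower numbers for a weaker effect. Compound 1 `O=c1[nH]nc2n(c1=O)CCN2c1ccccc1` carries no methyl group on its aromatic ring, and in this assay compound 1 gives 7%. Compound 2 `Cc1cccc(N2CCn3c2n[nH]c(=O)c3=O)c1C` carries two methyl groups on that ring, and in this assay compound 2 gives 18%. Of these two numbers, compound 2 stands higher, and its gap to compound 1 lies beyond the usual scatter of such measurements.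

Going by the values given here, the next compound, compound 3 `Cc1ccccc1N1CCn2c1n[nH]c(=O)c2=O`, keeps only one of the methyl groups. The change from compound 2 to compound 3 is hydrogen in place of methyl on an aromatic carbon; the place of the change is ortho to a methyl group and meta to a large group. Among the compounds with values here, no pair differing in one place has been measured, so the size of this step has to be estimated. Since compound 3 sits between compound 1 at 7% and compound 2 at 18% in its count of methyl groups, a number between those readings is expected. The step in this assay is expected to be a small decrease, near the edge of the scatter: a number 6 percentage points lower from compound 2 to compound 3 (within the scatter). Compound 3 is estimated to give 12% in this assay, with a likely range from 2% to 24%.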

Compound 3, a percentage reported as inhibition, at one concentration (the size of the read-out at that concentration, not a potency): 0%
Estimate against measurement, compound 3: 12 percentage points above; measured number below the stated range.
By their numbers in this assay, from the lowest: compounds 3 and 1 (each within the scatter of the next); then compound 2.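

In this assay, the methyl group that sits ortho to a methyl group and meta to a large group now has a step of its own: replacing it with hydrogen gives a number 18 percentage points lower from compound 2 to compound 3 (beyond the scatter) (a single-place change that can be read beyond the scatter). Going by these compounds alone, the methyl group that stays in compound 3 shows no such step, since the change on that carbon gives a number 7 percentage points lower from compound 1 to compound 3 (within the scatter), and one methyl group on the ring therefore cannot be told apart from none in this read-out. So the two methyl groups of this small set do not behave alike, and a single methyl group counts here only in the presence of the other, with no reason for this available from the data in hand.

Going by these compounds, what remains open is whether the higher reading of compound 2 belongs to methyl in particular or to any group on that aromatic carbon, a question that a chlorine atom, a methoxy group or a longer chain such as ethyl at the same place could answer. On these data alone, it is also open whether a methyl group on that carbon would give the same reading if the other methyl group were replaced by hydrogen.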